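A few compounds are considered here, and "the series" means these few. Any claim that something is new, unique, unknown or untested is made for them only; others in the source may bear on it.

Series notes, measured compounds in a functional assay on SGC-7901 cells (Homo sapiens) for antiproliferative activity, read by MTT assay, with a stated time of 72 h; a higher number here means a weaker inhibitor, a lower number a stronger inhibitor:
compound 1 `CCOc1ccc(-c2ccc3ncn(-c4cc(OC)c(OC)c(OC)c4)c3c2)cc1`; compound 1 gives 2970 nM
compound 2 `COc1ccccc1-c1ccc2ncn(-c3cc(OC)c(OC)c(OC)c3)c2c1`; compound 2 gives 5050 nM
compound 3 `COc1cc(-n2cnc3ccc(-c4ccc(C)cc4F)cc32)cc(OC)c1OC`; compound 3 gives 5650 nM

Compound 1 has the lowest of the three numbers, but its nearest neighbour is compound 2 with a 1.7-fold higher number from compound 1 to compound 2 (0.23 log units; within the scatter) and its furthest is compound 3 with a 1.9-fold higher number from compound 1 to compound 3 (0.28 log units; within the scatter), both within the scatter, so no ranking among the three is supported. Compound 2 and compound 3 are separated by a 1.1-fold higher number from compound 2 to compound 3 (0.05 log units; within the scatter). The three differ only in the aryl group attached to the shared core.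

Compound 4 `COc1cc(-n2cnc3ccc(-c4cccc(F)c4)cc32)cc(OC)c1OC` is not yet measured. Against compound 1 the change is 3-fluorophenyl in place of 4-ethoxyphenyl on an aromatic carbon. Among the compounds with values here, the steps that bear on it are the two other exchanges of the same aryl group in compound 1, which gave a 1.7-fold higher number from compound 1 to compound 2 (0.23 log units; within the scatter) and a 1.9-fold higher number from compound 1 to compound 3 (0.28 log units; within the scatter); neither moved the number beyond the scatter. A further aryl exchange at the same place is therefore expected to give a step of about a 1.5-fold higher number from compound 1 to compound 4 (0.18 log units; within the scatter), nominally toward a higher number but of a size within the scatter. For compound 4 the expected value in this assay is 4500 nM, with an estimated range from 2000 nM to 10000 nM.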

Compound 4, half-maximal inhibitory concentration: 2490 nM
Compound 4: middle estimate off by 1.8-fold (0.26 log units), on the high side; the range from low to high includes it.
By their numbers in this assay, from the lowest: compounds 4, 1, 2 and 3 (each within the scatter of the next, the first and the last beyond it).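

In this assay, within the data shown here, the 3-fluorophenyl group gives the first steps at this aryl position that lie beyond the scatter, both modest: a 2.3-fold lower number from compound 3 to compound 4 (0.36 log units; beyond the scatter) and a 2.0-fold lower number from compound 2 to compound 4 (0.31 log units; beyond the scatter). Against the 4-ethoxyphenyl group the same exchange gives only a 1.2-fold lower number from compound 1 to compound 4 (0.08 log units; within the scatter), so the position holds compound 4 level with compound 1 even though the entering group is the smaller by heavy atoms and counts no hydrogen-bond acceptor, while the leaving group counts one. Nothing available accounts for why these aryl groups separate as they do.

On these data alone, all four aryl groups carry only ethoxy, methoxy, methyl or fluoro substituents, so it stays open how a phenyl ring bearing an amine or a carboxylic acid, or a longer alkoxy chain than ethoxy, would read in this assay. An unsubstituted phenyl group at this place would show whether the fluorine of compound 4 contributes to its number at all.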